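The source may report more compounds than this note shows. Statements on the series, on what has been measured and on what is new or still open speak of the compounds shown alone.

Measured in an ADME assay on BHK-21 cells (Mesocricetus auratus) for cytotoxicity, read by MTT assay; a lower number here means that less compound is tolerated, a higher number that more compound is tolerated:
- compound 1 `C/C(=N\NC(N)=O)c1ccc2c(c1)nc(-c1ccccc1)n2C1CCCCC1`: > 100000 nM (a limit)
- compound 2 `C/C(=N\NC(N)=O)c1ccc2c(c1)nc(-c1ccc(Cl)cc1)n2C1CCCCC1`: > 100000 nM (a limit)

Compound 2 stands only at a limit, > 100000 nM, and gives no number. Among the compounds with values here, the series so far sits entirely at one end of the assay: the limit of > 100000 nM in this assay, at which 2 of the 2 values shown sit. The next compound is compound 3 `C/C(=N\NC(N)=O)c1ccc2c(c1)nc(-c1ccc(C(F)(F)F)cc1)n2C1CCCCC1`, a change of trifluoromethyl in place of chloro on an aromatic carbon, para to a large group, or 4-chlorophenyl to 4-(trifluoromethyl)phenyl. Within the data shown here, the only measured step that bears on this is a step that the two limits leave unreadable from compound 1 to compound 2, so no size can be carried over from it. It does show no drop into a readable value in this assay, and no step beyond the scatter is expected. The expected step is a number no higher from compound 2 to compound 3 (the limit leaves the size open). Compound 3 is estimated at 100000 nM, with an expected range of 40000 nM to 200000 nM, and a further limit is the likeliest report.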

Compound 3, half-maximal cytotoxic concentration: > 100000 nM
Compound 3: a limit, no number; the forecaster's own chance of this, stated with the estimate: 85%; the middle value lies on the limit itself.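

No new step can be read in this assay among compound 1, compound 2 and compound 3, since all three report only a limit: the limit of > 100000 nM in this assay, at which 3 of the 3 values shown sit. The compounds shown leave open how much compound is tolerated beyond that limit, and whether chloro or trifluoromethyl in place of hydrogen changes it at all.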